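Swapping the Piperidine Nitrogen Substituent for a Pyrrolidine Amide

The compounds below may be only part of what the source reports. "The series", "measured", "known", "first", "only" and "open" are said of these compounds alone.

Measured compounds:
Compound 1, `CN(C)c1ccc(C(=O)N2CCC(NS(=O)(=O)c3cc(S(=O)(=O)c4ccccc4)ccc3C(F)(F)F)CC2)cc1`: 190 nM
Compound 2, `N#Cc1cccc(S(=O)(=O)N2CCC(NS(=O)(=O)c3cc(S(=O)(=O)c4ccccc4)ccc3C(F)(F)F)CC2)c1`: 170 nM
Compound 3, `O=C(O)c1ccc(N2CCC(NS(=O)(=O)c3cc(S(=O)(=O)c4ccccc4)ccc3C(F)(F)F)CC2)cc1`: 230 nM

In an assay on U2OS cells for inhibition of secreted frizzled-related protein 1 (Homo sapiens), read by a luciferase reporter, with a stated time of 18 h (on this read-out higher numbers stand for an effect only at larger amounts of compound and lower numbers for an effect already at smaller amounts), the three compounds share one core and differ only in the group on an amine nitrogen in a ring. Compound 3 has the highest of the three numbers, but its separations from the others are small: a 1.2-fold higher number from compound 1 to compound 3 (0.08 log units; within the scatter) and a 1.4-fold higher number from compound 2 to compound 3 (0.13 log units; within the scatter) both stay within the scatter, as does a 1.1-fold lower number from compound 1 to compound 2 (0.05 log units; within the scatter). So far, then, changing this group has not moved the read-out beyond noise.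

Compound 4, `O=C([C@@H]1CCNC1)N1CCC(NS(=O)(=O)c2cc(S(=O)(=O)c3ccccc3)ccc2C(F)(F)F)CC1`, continues this series with a change at the same place: (pyrrolidin-3-yl)carbonyl in place of 4-carboxyphenyl on an amine nitrogen in a ring. All three measured steps bear on it, since each exchanges the group at this very position, and each was within the scatter. On that basis no step beyond the scatter is expected in this assay, in either direction, though the entering group is unlike any measured one, so the range is kept wide. Compound 4 is expected to give 250 nM, with a range from 100 nM to 700 nM. The expected step is a 1.1-fold higher number from compound 3 to compound 4 (0.04 log units; within the scatter).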

Compound 4, half-maximal effective concentration: 380 nM
Beside the measured number, compound 4's estimate is 1.5-fold (0.18 log units) below it; the range from low to high includes it.
By their numbers in this assay, from the lowest: compounds 2, 1, 3 and 4 (each within the scatter of the next, the first and the last beyond it).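

In this assay this position on the amine nitrogen now shows its first step beyond the scatter, a modest one: a 2.2-fold higher number from compound 2 to compound 4 (0.35 log units; beyond the scatter). Against the other two compounds the entering group stays within the scatter, with a 1.7-fold higher number from compound 3 to compound 4 (0.22 log units; within the scatter) and a 2.0-fold higher number from compound 1 to compound 4 (0.30 log units; within the scatter), so compound 4 separates from only one of the three. Compound 4 also shows that a group with no aromatic ring, here (pyrrolidin-3-yl)carbonyl, can sit at this place and still give a number close to those of compound 1 and compound 3.

No evidence at hand explains the step from compound 2 to compound 4. Still open, going by these compounds, is how the opposite stereocentre, or a methyl or acetyl group on the pyrrolidine nitrogen, would read here.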